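This account rests on a few compounds, and the source may have more. Where it says the series, first, only, none or still open, it means among the compounds named here.

Measured so far:
- compound 1 `Cc1cc(/C=C2\SC(=O)NC2=O)c(C)n1-c1ccc(C(F)(F)F)cc1`: 2600 nM in an assay on HEK293T cells for agonist activity at Bile acid receptor (Homo sapiens), read by reporter gene assay, with a stated time of 16 h; on this read-out lower numbers stand for an effect already at smaller amounts and higher numbers for an effect only at larger amounts of compound
- compound 2 `Cc1cc(/C=C2\SC(=O)NC2=O)c(C)n1-c1ccc(OC(F)(F)F)cc1`: 1700 nM in this assay

Compound 2 gives the lowest of the two numbers, but the step of a 1.5-fold lower number from compound 1 to compound 2 (0.18 log units; within the scatter) lies within the scatter, so the two stand level. Compound 3 `Cc1cc(/C=C2\SC(=O)NC2=O)c(C)n1-c1ccc(Cl)cc1` differs from compound 2 by chloro in place of trifluoromethoxy on an aromatic carbon. Going by the values given here, no measured step covers this change; the only step known, a 1.5-fold lower number from compound 1 to compound 2 (0.18 log units; within the scatter), swaps two groups at the same place with no effect beyond the scatter. For compound 3 no step beyond the scatter is therefore expected, with a 1.5-fold higher number from compound 2 to compound 3 (0.17 log units; within the scatter) as the estimated change. Compound 3 is estimated at 2500 nM, range 900 nM to 7000 nM.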

Compound 3, half-maximal effective concentration: 2300 nM
Beside the measured number, compound 3's estimate is 1.1-fold (0.04 log units) above it; measured number inside the range.
By their numbers in this assay, from the lowest: compounds 2, 3 and 1 (each within the scatter of the next).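

In this assay, chloro in place of trifluoromethoxy gives a 1.4-fold higher number from compound 2 to compound 3 (0.13 log units; within the scatter) and chloro in place of trifluoromethyl gives a 1.1-fold lower number from compound 1 to compound 3 (0.05 log units; within the scatter) as its step. At this position, then, a group of 1 heavy atom without fluorine stands level with both fluorinated groups, so the change in size among these three compounds leaves the number within the scatter. Nothing available explains this level result. Still open, as far as these compounds go, is whether an amine, a carboxylic acid or a longer alkyl chain at this position would shift the number beyond the scatter.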